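Cytotoxicity notes on a small set of close analogues

A few compounds are considered here, and "the series" means these few. Any claim that something is new, unique, unknown or untested is made for them only; others in the source may bear on it.

Compound 1 `CC(C)c1nc(-c2cnc3ccc(-c4ccc(N)cc4)cc3c2)no1` is assessed in a functional assay on RD cells (Homo sapiens) for inhibition, read by luminescence and ATP content, with a stated time of 72 h; on this read-out lower numbers stand for higher toxicity in this test and higher numbers for lower toxicity in this test. Compound 1 reaches only a limit of the assay, > 800 nM. Compound 2 `CC(C)(C)c1nc(-c2cnc3ccc(-c4ccc(N)cc4)cc3c2)no1` likewise reaches only a limit, > 7400 nM. The change from compound 2 to compound 1 is hydrogen in place of methyl on a saturated chain carbon bound to an aromatic carbon and two saturated chain carbons; the step that the two limits leave unreadable from compound 2 to compound 1 cannot be read because the limit of > 7400 nM in this assay, at which 2 of the 3 values shown sit, and the limit of > 800 nM in this assay, at which 1 of the 3 values shown sits, bound it. Compound 3 `CCCCc1ccc(-c2ccc3ncc(-c4noc(CC)n4)cc3c2)cc1` also sits at a limit, > 7400 nM. The difference between the core of compound 3 and that of compound 2 is not broken down here. Compound 4 `CCCc1ccc(-c2ccc3ncc(-c4noc(CC)n4)cc3c2)cc1` is not yet measured; it differs from compound 3 by hydrogen in place of methyl on a saturated chain carbon, three bonds along the chain from an aromatic carbon, the same kind of change as that from compound 2 to compound 1, but on a saturated chain carbon three bonds along the chain from an aromatic carbon rather than on one bound to an aromatic carbon and two saturated chain carbons. Compound 4 is expected to stay near the limit, with a step that the limit leaves unreadable from compound 3 to compound 4. This rests on compound 3 giving > 7400 nM, a limit, and on the step that the two limits leave unreadable from compound 2 to compound 1 being unreadable. The estimate for compound 4 is 9000 nM, expected between 3000 nM and 30000 nM.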

Compound 4, half-maximal cytotoxic concentration: > 7400 nM
Compound 4 gave a limit, no number (the forecaster's own chance of this, stated with the estimate: 80%); the middle value does not contradict the limit.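

No step can be read from compound 3 to compound 4 in this assay, as both values are limits: the limit of > 7400 nM in this assay, at which 3 of the 4 values shown sit.

The compounds shown leave open whether hydrogen in place of methyl changes the half-maximal cytotoxic concentration at all.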